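This account rests on a few compounds, and the source may have more. Where it says the series, first, only, none or still open, it means among the compounds named here.

Compound 2, with structure `CCOC(=O)c1cnc2scc(C3=CCCCC3)n12`, carries a cyclohex-1-en-1-yl group on the shared core. In an assay on isolated protein for inhibition of Indoleamine 2,3-dioxygenase 1 (Homo sapiens), with a stated time of 30 min (on this read-out higher numbers stand for weaker inhibition and lower numbers for stronger inhibition), compound 2 gives only a limit, > 100000 nM, and not a number. Compound 1, with structure `CCOC(=O)c1cnc2scc(-c3cccc(C)c3)n12`, also gives only a limit in this assay, > 100000 nM. A different picture comes from compound 3, with structure `COc1ccc(NC(=O)NCc2cnc3scc(-c4ccc(Br)cc4)n23)cc1`, which gives 190 nM in this assay. So compound 2 stands among the weak end of what has been measured, since two of the three values rest on the same limit (the limit of > 100000 nM in this assay, at which 2 of the 3 values shown sit).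

Compound 4, with structure `CCOC(=O)c1cnc2scc(-c3ccccc3)n12`, is not yet measured. It differs from compound 2 by one change: phenyl in place of cyclohex-1-en-1-yl on an aromatic carbon. The closest measured relative of compound 4 is compound 1, which differs from it only by a methyl on the phenyl and sits at the limit. Compound 4 is therefore expected to remain at that limit, and the step of a number no higher from compound 2 to compound 4 (the limit leaves the size open) is expected to be none beyond the scatter. The estimate for compound 4 is 100000 nM, within a range from 30000 nM to 300000 nM.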

Compound 4, half-maximal inhibitory concentration: > 100000 nM
Compound 4: only a limit was reported (the forecaster's own chance of this, stated with the estimate: 85%); the middle value lies on the limit itself.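

No step can be read from compound 2 to compound 4 or from compound 1 to compound 4, because all three compounds give a limit and not a number: the limit of > 100000 nM in this assay, at which 3 of the 4 values shown sit. The compounds shown leave open whether phenyl, cyclohex-1-en-1-yl or an added methyl makes any real difference to inhibition.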